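Swapping one aryl group on a tolerated core

This account rests on a few compounds, and the source may have more. Where it says the series, first, only, none or still open, it means among the compounds named here.

Compound 1 `COc1ccc(/C=C2\CCC/C(=C\c3ccc(N(C)C)cc3)C2=O)cc1`: 392000 nM
Compound 2 `COc1ccc(/C=C2\CCC/C(=C\c3ccc([N+](=O)[O-])cc3)C2=O)cc1`: 435000 nM
Compound 3 `COc1ccc(/C=C2\CCC/C(=C\c3ccccc3Cl)C2=O)cc1`: 238000 nM

These three compounds were measured in an ADME assay on Vero cells (Chlorocebus sabaeus) for inhibition (a higher number here means that more compound is tolerated, a lower number that less compound is tolerated), and their numbers lie close together. In this assay compound 3 gives 238000 nM, a number within the usual scatter of those for compound 1 and compound 2, so the data set no order among the three.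

The next compound is compound 4 `COc1ccc(/C=C2\CCC/C(=C\c3ccc(Br)cc3)C2=O)cc1`, which has 4-bromophenyl in place of 2-chlorophenyl on a double-bonded chain carbon bound to a double-bonded ring carbon. Among the measured compounds shown here, no measured compound carries either a bromine or a second example of this exact exchange, so the evidence is indirect.

For the measured compounds named here, only one measured step bears on it, a 1.1-fold higher number from compound 1 to compound 2 (0.05 log units; within the scatter), where nitro replaces dimethylamino on an aromatic carbon. Even that exchange of very different groups stayed small. On the strength of that step, and of the narrow spread of the three values, no change beyond the scatter is expected here. The expected step is a 1.3-fold higher number from compound 3 to compound 4 (0.10 log units; within the scatter), and it is estimated to stay within the scatter. The estimated value for compound 4 is 300000 nM, with an expected range from 150000 nM to 550000 nM.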

Compound 4, half-maximal cytotoxic concentration: 250000 nM
Estimate against measurement, compound 4: 1.2-fold (0.08 log units) above; the range from low to high includes it.
By their numbers in this assay, from the lowest: compounds 3, 4, 1 and 2 (each within the scatter of the next).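

Among the compounds shown here, the exchange of 2-chlorophenyl for 4-bromophenyl on a double-bonded chain carbon bound to a double-bonded ring carbon gives, in this assay, a small step (a 1.1-fold higher number from compound 3 to compound 4 (0.02 log units; within the scatter)), the first direct reading of a halogen-bearing aryl group at this place. For the compounds shown here, compound 4 also adds two comparisons on an aromatic carbon, bromo in place of nitro (a 1.7-fold lower number from compound 2 to compound 4 (0.24 log units; within the scatter)) and bromo in place of dimethylamino (a 1.6-fold lower number from compound 1 to compound 4 (0.20 log units; within the scatter)), so all four aryl groups seen here, on the shared core, fall within the scatter of one another and no compound goes against that. The data offer no measured basis for explaining why these exchanges leave the number so little changed.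

Since 2-chlorophenyl and 4-bromophenyl differ in both the halogen and its place on the ring, this step cannot separate the two, and 4-chlorophenyl would be needed to do so. Going by these compounds, it also remains open whether a carboxylic acid, a primary amine or a longer chain on this aryl group would stay within the scatter, and whether the methoxyphenyl group on the other side of the shared core can be exchanged as freely.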